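A few compounds are considered here, and "the series" means these few. Any claim that something is new, unique, unknown or untested is made for them only; others in the source may bear on it.

Of the compounds shown here, two have been measured in an assay on CHO-K1 cells for antagonist activity at transient receptor potential cation channel subfamily V member 1 (Homo sapiens), read by FLIPR and calcium flux, with a stated time of 6 min; on this read-out higher numbers stand for weaker inhibition and lower numbers for stronger inhibition. Compound 1 `Cn1ncc2c(NC(=O)NCc3cc(C(F)(F)F)nn3-c3ccc(F)cc3)cccc21` gives 8.4 nM. Compound 2 `Cn1ncc2c(NC(=O)NCc3cc(C(C)(C)C)nn3-c3cccc(C(F)(F)F)c3)cccc21` gives 0.6 nM, the lowest of the two numbers, and the nearest number, that of compound 1, is higher by a margin beyond the scatter. Compound 3 `Cn1ncc2c(NC(=O)NCc3cc(C(C)(C)C)nn3-c3ccc(F)cc3)cccc21` has not yet been measured. It differs from compound 2 in one place: 4-fluorophenyl in place of 3-(trifluoromethyl)phenyl on an aromatic nitrogen. Among the compounds with values here, compound 3 thus carries the same aryl group on the ring nitrogen as compound 1 while keeping the tert-butyl group of compound 2; compound 1 and compound 2 differ in both places, so no single step between measured compounds shows how much either change alone counts. The step from compound 2 to compound 3 is expected to be a 5.0-fold higher number from compound 2 to compound 3 (0.70 log units; beyond the scatter), toward a higher number, since compound 1 shows 8.4 nM with the same 4-fluorophenyl group. Compound 3 is estimated at 3 nM, with a likely range from 1 nM to 10 nM.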

Compound 3, inhibition constant: 4.5 nM
The estimate for compound 3 lay 1.5-fold (0.18 log units) below the measured number, within the range that was stated.
By their numbers in this assay, from the lowest: compound 2; then compounds 3 and 1 (each within the scatter of the next).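

With tert-butyl held fixed, replacing 3-(trifluoromethyl)phenyl with 4-fluorophenyl on the aromatic nitrogen gives a 7.5-fold higher number from compound 2 to compound 3 (0.88 log units; beyond the scatter), so the aryl group at this position matters on its own. The other single change, tert-butyl in place of trifluoromethyl on an aromatic carbon, gives a 1.9-fold lower number from compound 1 to compound 3 (0.27 log units; within the scatter), so with 4-fluorophenyl on the nitrogen, this swap shows no clear difference. No measurement at hand explains either result.

The two aryl groups differ in both the substituent and where it sits on the ring, so these compounds cannot separate those two features; a plain phenyl or a 4-(trifluoromethyl)phenyl group would be needed to do so. As far as these compounds go, it also remains open whether trifluoromethyl and tert-butyl would stay this close with 3-(trifluoromethyl)phenyl on the nitrogen.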